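The source may hold more compounds than are shown below. What is called first, only, known or untested is meant among the compounds shown, and "the series" means these compounds.

Compound 1 `C#CCOc1ccc2c(=O)c(-c3cc(OC)c(OC)cc3OC)coc2c1`: 4950 nM
Compound 2 `COc1cc(OC)c(-c2coc3cc(OCc4ccccc4C(F)(F)F)ccc3c2=O)cc1OC`: 6550 nM

Going by the values given here, in a functional assay on HepG2 cells (Homo sapiens) for antiproliferative activity, read by MTT assay, with a stated time of 24 h (on this read-out higher numbers stand for weaker inhibition and lower numbers for stronger inhibition), compound 1 stands at 4950 nM, and the only measured step away from it, a 1.3-fold higher number from compound 1 to compound 2 (0.12 log units; within the scatter), leaves compound 1 and compound 2 indistinguishable. Compound 3 `COc1cc(OC)c(-c2coc3cc(OCc4ccccc4Cl)ccc3c2=O)cc1OC` carries the change (2-chlorophenyl in place of ethynyl on a saturated chain carbon bound to an oxygen on an aromatic ring). Among the compounds with values here, the step from compound 1 to compound 2 is the one measured step that bears on this, a change of the same kind at the same place, and it stayed within the scatter. Compound 3 is therefore expected to remain close to compound 1, with a 1.2-fold higher number from compound 1 to compound 3 (0.08 log units; within the scatter) amounting to no shift beyond the scatter, and its estimated value is 6000 nM (range 2500 nM to 14000 nM).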

Compound 3, half-maximal inhibitory concentration: 1690 nM
For compound 3 the middle estimate is 3.6-fold (0.55 log units) above the measured one; the whole stated range lies above it.
By their numbers in this assay, from the lowest: compound 3; then compounds 1 and 2 (each within the scatter of the next).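

In this assay, the group on the saturated chain carbon bound to an oxygen on an aromatic ring can shift the number beyond the scatter, as the earlier pair did not show: the change gives a 2.9-fold lower number from compound 1 to compound 3 (0.47 log units; beyond the scatter) in this series. The group on the aromatic carbon also counts, with a 3.9-fold lower number from compound 2 to compound 3 (0.59 log units; beyond the scatter) for chloro in place of trifluoromethyl, so a substituted phenyl in place of ethynyl does not have one fixed outcome. No measurement offered here accounts for this difference.

Going by these compounds, whether an amine or a carboxylic acid in place of chloro would keep the lower number remains open. So does the effect of a longer chain in place of propargyl.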